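The compounds below may be only part of what the source reports. "The series", "measured", "known", "first", "only" and "open" are said of these compounds alone.

The series begins with compound 1 `Cc1cccc(C(=O)/C=C/CCc2ccccc2)c1`. In a functional assay on HEK293 cells for antagonist activity at G-protein coupled receptor 52 (Homo sapiens), read by cAMP accumulation, with stated times of 15 min and 30 min (a higher number here means a weaker inhibitor, a lower number a stronger inhibitor), compound 1 gives 2570 nM, the lowest of the two numbers recorded so far. Its nearest neighbour is compound 2 `Cc1ccc(C(=O)/C=C/CCc2ccccc2)cc1`, which in this assay gives 3020 nM; the two values lie within the usual scatter of this kind of measurement, so neither compound can be set ahead of the other. Going by the values given here, no pair of measured compounds that differ at a single position is available, so there is no measured step to lean on.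

Compound 3 `O=C(/C=C/CCc1ccccc1)c1cccc(-c2ccccc2)c1` has not yet been tested in this assay. It differs from compound 1 in one place: phenyl in place of methyl on an aromatic carbon. The phenyl sits on an aromatic carbon of a six-membered aromatic ring of carbon only, where compound 1 carries a methyl.

With nothing measured to guide the estimate, the step is expected to be modest, a 1.4-fold lower number from compound 1 to compound 3 (0.15 log units; within the scatter), leaning toward a somewhat stronger inhibitor but with little confidence in the direction. For compound 3 the value in this assay is estimated at 1800 nM, with a plausible range from 500 nM to 7000 nM.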

Compound 3, half-maximal inhibitory concentration: 8130 nM
For compound 3 the middle estimate is 4.5-fold (0.65 log units) below the measured one; measured number outside the range, above it.
By their numbers in this assay, from the lowest: compounds 1 and 2 (each within the scatter of the next); then compound 3.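

In this assay, going by these compounds alone, the earlier compounds offered no measured step, and this change now supplies one: phenyl in place of methyl on an aromatic carbon, meta to a large group, gives a 3.2-fold higher number from compound 1 to compound 3 (0.50 log units; beyond the scatter). The position is therefore not indifferent to what it carries, and in this one comparison the larger group weakens inhibition by a margin beyond the scatter, though compound 3 still gives a measurable 8130 nM. Nothing available explains the loss, and no measurement on the compounds points to a cause for it.

A single step cannot say whether the loss tracks the number of heavy atoms added or belongs to the phenyl ring itself, so an ethyl group, a methoxy group, a chlorine atom or a pyridine ring at this place remains an open comparison. On these data alone, it is also open whether phenyl in place of the methyl of compound 2 would move the number the same way, and whether an amine or a carboxylic acid on the added phenyl would change the outcome.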